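Chalcone-type analogues tested against a colon carcinoma cell line

The source may hold more compounds than are shown below. What is called first, only, known or untested is meant among the compounds shown, and "the series" means these compounds.

Measured compounds:
compound 1 `COc1ccc(C(=O)/C=C/c2ccc3ccccc3n2)c2c1C=CC(C)(C)O2` gives 2250 nM
compound 2 `COc1ccc(C(=O)/C=C/c2cccc([N+](=O)[O-])c2)c2c1C=CC(C)(C)O2` gives 4090 nM
compound 3 `COc1ccc(C(=O)/C=C/c2cccc(C(F)(F)F)c2)c2c1C=CC(C)(C)O2` gives 7870 nM

Of the compounds shown here, three sharing one core have been measured in a functional assay on SW-620 cells (Homo sapiens) for antiproliferative activity, read by MTT assay, with a stated time of 24 h; a lower number here means a stronger inhibitor, a higher number a weaker inhibitor. Compound 2 stands second highest of the three numbers. Its nearest neighbour is compound 1, and the gap between them lies within the scatter; its furthest is compound 3, and that gap too lies within the scatter. The one measured step that differs in a single place, a 1.9-fold higher number from compound 2 to compound 3 (0.28 log units; within the scatter), is also within the scatter, so among these three compounds no ordering can be read.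

Compound 4 `COc1ccc(C(=O)/C=C/c2ccc(Cl)c(Cl)c2)c2c1C=CC(C)(C)O2` is the unmeasured analogue. It differs from compound 2 in one place: 3,4-dichlorophenyl in place of 3-nitrophenyl on a double-bonded chain carbon bound to a double-bonded chain carbon

Among the compounds with values here, the only step that bears on this change is the step from compound 2 to compound 3, where a group on the same aromatic ring was exchanged and the number moved within the scatter. Within the data shown here, no measured step exchanges a nitro for chlorines, and none adds a second substituent to that ring, so the data give no direction for this change.

Compound 4 is therefore expected to give a number close to that of compound 2, with a step of a 1.1-fold higher number from compound 2 to compound 4 (0.04 log units; within the scatter), and the estimate is 4500 nM, ranging from 1800 nM to 11000 nM.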

Compound 4, half-maximal inhibitory concentration: 7700 nM
The estimate for compound 4 lay 1.7-fold (0.23 log units) below the measured number, and the stated range covers the measured number.
By their numbers in this assay, from the lowest: compounds 1, 2, 4 and 3 (each within the scatter of the next, the first and the last beyond it).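

At this position, on a double-bonded chain carbon bound to a double-bonded chain carbon, the exchange of 3-nitrophenyl for 3,4-dichlorophenyl gives a 1.9-fold higher number from compound 2 to compound 4 (0.27 log units; within the scatter) in this assay, so a ring with two substituents and no hydrogen-bond acceptors still gives no step beyond the scatter. With a 1.9-fold higher number from compound 2 to compound 3 (0.28 log units; within the scatter) as the earlier step, both exchanges measured from compound 2 now lie within the scatter, and neither gives a direction that can be read for changes on this aromatic ring. Nothing available explains this result or links it to any property of the groups involved.

The compounds shown leave open whether an amine, a hydroxyl or a carboxylic acid on this aromatic ring would give a step beyond the scatter, since every exchange measured from compound 2 so far keeps a ring carrying only nitro, trifluoromethyl or chlorine. They also leave open how much the methoxy group or the two methyl groups of the shared core contribute, as all of the compounds keep that core unchanged.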